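This account rests on a few compounds, and the source may have more. Where it says the series, first, only, none or still open, it means among the compounds named here.

Measured in a functional assay on BGC-823 cells (Homo sapiens) for antiproliferative activity, read by MTT assay, with a stated time of 48 h; on this read-out lower numbers stand for stronger inhibition and higher numbers for weaker inhibition:
- compound 1 `Brc1ccccc1CSc1nnc(-c2cnccn2)n1-c1ccccc1`: 36200 nM
- compound 2 `Brc1cccc(CSc2nnc(-c3cnccn3)n2-c2ccccc2)c1`: 18300 nM
- compound 3 `Fc1ccc(CSc2nnc(-c3cnccn3)n2-c2ccccc2)c(F)c1`: 17800 nM

Compound 3 stands at the low end of this small set, level with its nearest neighbour: a 1.0-fold lower number from compound 2 to compound 3 (0.01 log units; within the scatter). Its furthest neighbour lies a modest distance away: a 2.0-fold lower number from compound 1 to compound 3 (0.31 log units; beyond the scatter).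

The next compound to be tested is compound 4 `Fc1cccc(F)c1CSc1nnc(-c2cnccn2)n1-c1ccccc1`. It carries 2,6-difluorophenyl in place of 2,4-difluorophenyl on a saturated chain carbon bound to a sulfur. The two compounds have the same atoms, joined differently.

All three measured steps exchange the group at this same place, so all three bear on the question. They are small: apart from the two above, the third reads a 2.0-fold lower number from compound 1 to compound 2 (0.30 log units; within the scatter). Even the largest only just clears the usual scatter. Going by the values given here, none of them compares two difluorophenyl groups, so the data offer no direct precedent and no firm direction.

A small change is therefore the reasonable expectation, and the expected step in this assay is a 1.1-fold higher number from compound 3 to compound 4 (0.05 log units; within the scatter), which would not stand out from the scatter. Compound 4 is estimated at 20000 nM, with an expected range from 9500 nM to 40000 nM.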

Compound 4, half-maximal inhibitory concentration: > 50000 nM
Compound 4: no number, only a limit; the forecaster's own chance of this, stated with the estimate: 4%; middle value at least 2.5-fold (0.39 log units) from the limit.
By their numbers in this assay, from the lowest: compounds 3, 2 and 1 (each within the scatter of the next, the first and the last beyond it). At a limit, above all of these: compound 4.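

In this assay, compound 4 has no exact number, only a limit of the assay: the limit of > 50000 nM in this assay, at which 1 of the 4 values shown sits. Even so, the limit is enough to show that this position is sensitive to how the substituents are arranged on the ring, and not only to which atoms are present: with the same atoms, 2,6-difluorophenyl in place of 2,4-difluorophenyl gives an at least 2.8-fold higher number from compound 3 to compound 4 (0.44 log units; beyond the scatter), and the change from the 3-bromophenyl group gives an at least 2.7-fold higher number from compound 2 to compound 4 (0.43 log units; beyond the scatter), both beyond the scatter, whereas the earlier steps at this place barely cleared it. The comparison with the 2-bromophenyl group is less decisive, since an at least 1.3-fold higher number from compound 1 to compound 4 (0.14 log units; that floor lies within the scatter) is a floor that lies within the scatter, so these two compounds cannot yet be placed in order.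

Going by these compounds, how far the true value of compound 4 lies past its limit remains unknown, so the full size of these steps is open. On these data alone, it is also open how a plain phenyl, a 2,6-dichlorophenyl or a 3,5-difluorophenyl group, or a longer chain between the sulfur and the ring, would behave at this place.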